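The source may hold more compounds than are shown below. What is called first, only, known or untested is meant among the compounds shown, and "the series" means these compounds.

Measured compounds:
Compound 1, `CC(=O)c1cc(CC(C)O)c(OCCCCC#N)cc1O`: 6%
Compound 2, `C=CCc1cc(C(C)=O)c(O)cc1OCC#N`: 2%
Compound 3, `C=CCc1cc(C(C)=O)c(O)cc1OCCCC#N`: 6%

All three were tested in an assay on isolated protein for binding affinity to leukotriene B4 receptor 1 (Homo sapiens), tested at 1 uM; on this read-out higher numbers stand for more inhibition at the one concentration tested (going by the name of the read-out) and lower numbers for less inhibition. Compound 3 shows the same number as compound 1, and compound 2 lies within the scatter of both, so the three measured compounds cannot be told apart on these numbers. Going by the values given here, the one step between single-change neighbours is a number 4 percentage points higher from compound 2 to compound 3 (within the scatter), which lengthens the chain that carries the nitrile.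

Compound 4, `C=CCc1cc(C(C)=O)c(O)cc1OCCCCCC#N`, has not yet been measured in this assay. It differs from compound 3 in one place: 2-cyanoethyl in place of cyano on a saturated chain carbon, three bonds along the chain from an oxygen on an aromatic ring. This is the same kind of lengthening of the nitrile-bearing chain as the step from compound 2 to compound 3, only carried one stage further out. Among the compounds with values here, that measured step stayed within the scatter, and nothing among the measured compounds points to a change in the other direction. The expectation is therefore no step beyond the scatter in this assay, with the estimate no change at the digits printed from compound 3 to compound 4 (within the scatter). Compound 4 is expected to give about 6%, between 0% and 16%. What compound 4 actually gives in this assay is reported next.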

Compound 4, a percentage reported as inhibition, at one concentration (the size of the read-out at that concentration, not a potency): 41%
The estimate for compound 4 lay 35 percentage points below the measured number; measured number above the stated range.
By their numbers in this assay, from the lowest: compounds 2, 1 and 3 (each within the scatter of the next); then compound 4.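

Going from a number 35 percentage points higher from compound 3 to compound 4 (beyond the scatter) in this assay shows that the length of the nitrile-bearing chain on the oxygen of the aromatic ring does matter, which the shorter compounds gave no sign of. Across the whole series, 4-cyanobutyl in place of cyano gives a number 39 percentage points higher from compound 2 to compound 4 (beyond the scatter), whereas the first extension gave only a number 4 percentage points higher from compound 2 to compound 3 (within the scatter), so among these three compounds the gain does not build evenly and appears only with the last extension. No measurement available here explains why the response to chain length is so uneven.

The compounds shown leave open whether a longer chain would raise the number further or lower it again, and whether the nitrile at the chain end is needed at all or a carboxylic acid or an amine there would do as well. They also leave open how potent compound 4 is, since a single percentage at one concentration marks a clear difference from its shorter neighbours but is not a measure of potency.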